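The source may report more compounds than this note shows. Statements on the series, on what has been measured and on what is new or still open speak of the compounds shown alone.

Compound 3 (`CNc1ccnc2c(O)c(-c3nc(C)n[nH]3)ncc12`) gives > 50100 nM in a toxicity assay on THP-1 cells (Homo sapiens) for cytotoxicity (a lower number here means that less compound is needed, a higher number that more compound is needed for the effect), which is a limit and not a number. Compound 2 (`Oc1c(-c2nc(C(O)c3ccccc3)n[nH]2)ncc2cccnc12`) gives > 50100 nM, also a limit. Compound 3 therefore sits at the limit of > 50100 nM in this assay, at which 2 of the 3 values shown sit. For the measured compounds named here, compound 1 (`Oc1c(-c2nnc(Cc3ccc(Cl)cc3)[nH]2)ncc2cccnc12`) gives 31600 nM, the only actual number. In compound 4 (`Cc1n[nH]c(-c2ncc3c(N4CCCCS4(=O)=O)ccnc3c2O)n1`), the methylamino on an aromatic carbon gives way to a group with one six-membered non-aromatic ring with 2 hetero atoms: a group of 8 heavy atoms (4 carbon, 1 nitrogen, 2 oxygen, 1 sulfur; one six-membered non-aromatic ring with 2 hetero atoms) in place of a group of 2 heavy atoms (1 carbon, 1 nitrogen; no ring), on an aromatic carbon. Going by the values given here, no measured step exists to size this change, so no shift beyond the usual scatter is expected in this assay: the expected step is an at least 1.1-fold lower number from compound 3 to compound 4 (0.07 log units; that floor lies within the scatter). The estimate for compound 4 is 42000 nM, with an expected range of 18000 nM to 50100 nM.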

Compound 4, half-maximal effective concentration: > 50100 nM
Compound 4 was reported as a limit (the forecaster's own chance of this, stated with the estimate: 60%); middle value at least 1.1-fold (0.07 log units) from the limit.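

Compound 3 and compound 4 are both reported only as limits, so no step can be read between them in this assay: the limit of > 50100 nM in this assay, at which 3 of the 4 values shown sit.

The compounds shown leave open whether exchanging the methylamino for the six-membered non-aromatic ring group changes the value at all.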